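Amide variation on the shared core: compound 2 to compound 3

This account rests on a few compounds, and the source may have more. Where it says the series, first, only, none or still open, it means among the compounds named here.

compound 1 `CCCCNC(=O)c1c(N)sc(-c2ccc(Cl)cc2)c1-c1ccc(Cl)cc1` gives 8170 nM
compound 2 `CC(C)CNC(=O)c1c(N)sc(-c2ccc(Cl)cc2)c1-c1ccc(Cl)cc1` gives 21000 nM

Both values come from a functional assay on A549 cells (Homo sapiens) for inhibition, read by sulforhodamine B assay, with a stated time of 72 h; a lower number here means a stronger inhibitor, a higher number a weaker inhibitor. Of the two measured compounds, compound 2 stands highest, at 21000 nM, and so is the weaker inhibitor on these numbers. Going by the values given here, the only measured step is a 2.6-fold higher number from compound 1 to compound 2 (0.41 log units; beyond the scatter). It is modest yet beyond the scatter, and it concerns the chain on the amide-type nitrogen.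

Compound 3 `Nc1sc(-c2ccc(Cl)cc2)c(-c2ccc(Cl)cc2)c1C(=O)N1CCC(=O)CC1=O` is the next to be read. Its change sits at the same part of the molecule but is much larger: 2,4-dioxopiperidin-1-yl in place of isobutylamino on a carbonyl carbon. Among the compounds with values here, no measured compound carries this group, and a single step on a chain says little about replacing the whole amine portion. Going by these compounds, the direction therefore stays open, and no step beyond the scatter is the central expectation, with a wide margin either way. The expected step is a 1.4-fold lower number from compound 2 to compound 3 (0.15 log units; within the scatter). In this assay the estimate for compound 3 is 15000 nM, with an expected range from 5000 nM to 50000 nM.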

Compound 3, half-maximal inhibitory concentration: 4090 nM
For compound 3 the middle estimate is 3.7-fold (0.56 log units) above the measured one; the whole stated range lies above it.
By their numbers in this assay, from the lowest: compounds 3 and 1 (each within the scatter of the next); then compound 2.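

In this assay, putting 2,4-dioxopiperidin-1-yl in place of isobutylamino on the carbonyl carbon gives a 5.1-fold lower number from compound 2 to compound 3 (0.71 log units; beyond the scatter) and so shows that this position accepts far more than a change of chain: a six-membered non-aromatic ring with 0 hydrogen-bond donors and 2 hydrogen-bond acceptors can replace the whole amine portion, and the amide hydrogen is not needed to reach this level in the compounds shown. Set against the straight chain, the same replacement gives a 2.0-fold lower number from compound 1 to compound 3 (0.30 log units; within the scatter) and so separates compound 3 from butylamino by no real margin, which means the clear step holds only against isobutylamino and the ring offers no demonstrated advantage over the best chain in hand. Nothing available bears on the reason for either step.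

Which part of the new group carries the result stays open, since a plain piperidin-1-yl or a 4-oxopiperidin-1-yl group would show whether the ring alone or its carbonyl groups matter. Going by these compounds, it is also open whether a morpholin-4-yl ring or a longer straight chain on the amide nitrogen would move the number beyond the scatter of compound 1 and compound 3.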